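The source may report more compounds than this note shows. Statements on the series, on what has been measured and on what is new or still open speak of the compounds shown alone.

Three compounds measured in a functional assay on ACHN cells (Homo sapiens) for cytotoxicity, read by MTT assay, with a stated time of 48 h (on this read-out lower numbers stand for stronger inhibition and higher numbers for weaker inhibition), frame the question. Compound 1 `COc1cc(-c2cc(C(=O)Nc3nc4ccc(F)cc4s3)nc3cc(-c4ccccc4)nn23)cc(OC)c1OC` gives 32400 nM. Compound 2 `COc1ccc2nc(NC(=O)c3cc(-c4ccc(F)cc4)n4nc(-c5ccccc5)cc4n3)sc2c1` gives 26300 nM, and compound 3 `COc1ccc2nc(NC(=O)c3cc(-c4ccc(OC)c(OC)c4)n4nc(-c5ccccc5)cc4n3)sc2c1` gives 13300 nM. Compound 3 carries the lowest of these three numbers, though its gap to compound 2 is within the scatter and only its gap to compound 1 is beyond it. The one single-site step shown, a 2.0-fold lower number from compound 2 to compound 3 (0.30 log units; within the scatter), swapped the group on the shared core and stayed within the scatter.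

Compound 4 `COc1ccc2nc(NC(=O)c3cc(-c4cc(OC)c(OC)c(OC)c4)n4nc(-c5ccccc5)cc4n3)sc2c1` differs from compound 3 by methoxy in place of hydrogen on an aromatic carbon. Among the compounds with values here, no measured step matches this exact change. Compound 1 also bears a 3,4,5-trimethoxyphenyl, but it differs from compound 3 in a second place as well, so its higher number cannot be laid to the trimethoxy group alone. Given that the one shown step was within the scatter, compound 4 is expected to show a 1.4-fold higher number from compound 3 to compound 4 (0.13 log units; within the scatter), with no change beyond the scatter in this assay. Compound 4 is therefore estimated at 18000 nM, within a range of 7000 nM to 45000 nM.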

Compound 4, half-maximal inhibitory concentration: 5240 nM
Beside the measured number, compound 4's estimate is 3.4-fold (0.54 log units) above it; measured number outside the range, below it.
By their numbers in this assay, from the lowest: compound 4; then compounds 3, 2 and 1 (each within the scatter of the next, the first and the last beyond it).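

On this assay the added methoxy on the 3,4-dimethoxyphenyl gives a 2.5-fold lower number from compound 3 to compound 4 (0.40 log units; beyond the scatter) and is the first single-site change shown here to go beyond the scatter, so this position does respond to a methoxy group. Swapping 4-fluorophenyl for 3,4,5-trimethoxyphenyl gives a 5.0-fold lower number from compound 2 to compound 4 (0.70 log units; beyond the scatter) and shows the larger change at the same site, while the trimethoxy group alone does not set the number, since with it held fixed, methoxy in place of fluoro at the other site gives a 6.2-fold lower number from compound 1 to compound 4 (0.79 log units; beyond the scatter) in the same direction. Nothing available here accounts for these steps.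

The compounds shown leave open whether another group at this position, such as a hydroxyl, an amine or a longer ethoxy chain, would lower the number as far. They also leave open whether the added methoxy would give a similar step with fluoro at the other site.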